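The source may report more compounds than this note shows. Statements on the series, on what has been measured and on what is new or still open speak of the compounds shown alone.

Measured compounds:
Compound 1, `O=S(=O)(/C=C/c1ccccc1)Cc1ccc(Nc2ncnc3ccccc23)cc1`: in a functional assay on HT-29 cells (Homo sapiens) (on this read-out lower numbers stand for stronger inhibition of growth and higher numbers for weaker inhibition of growth), compound 1 gives > 100000 nM, which is a limit of the assay rather than a number.
Compound 2, `O=S(=O)(/C=C/c1ccc(Cl)c(Cl)c1)Cc1ccc(Nc2ncnc3ccccc23)cc1`: in this assay compound 2 gives 11000 nM.

Compound 1 thus stands at the limit that this assay can report (the limit of > 100000 nM in this assay, at which 1 of the 2 values shown sits). Compound 3, `O=S(=O)(/C=C/c1ccc(O)cc1)Cc1ccc(Nc2ncnc3ccccc23)cc1`, differs from compound 1 by hydroxy in place of hydrogen on an aromatic carbon. Among the measured compounds shown here, the only measured step on that ring, an at least 9.0-fold lower number from compound 1 to compound 2 (0.95 log units; beyond the scatter), introduced a different group, so it guides the expectation only loosely. Some move toward stronger inhibition of growth seems plausible but uncertain, and the expected step is an at least 2.0-fold lower number from compound 1 to compound 3 (0.30 log units; that floor lies within the scatter). Compound 3 is therefore estimated at 50000 nM, with a range from 10000 nM to 200000 nM.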

Compound 3, concentration for 50% growth inhibition: 2000 nM
The estimate for compound 3 lay 25-fold (1.40 log units) above the measured number; measured number below the stated range.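

A single hydroxy on the aromatic ring, para to a large group, brings a large gain in growth inhibition in this assay: an at least 50-fold lower number from compound 1 to compound 3 (1.69 log units; beyond the scatter). The same small group also outperforms the two chlorines of the 3,4-dichlorophenyl ring, with a 5.5-fold lower number from compound 2 to compound 3 (0.74 log units; beyond the scatter), so a gain at this ring does not depend on having chlorine there. Compound 1 stands at a limit, so the first step gives only a floor: the limit of > 100000 nM in this assay, at which 1 of the 3 values shown sits.

The compounds shown leave open whether hydroxy itself is needed. A methoxy or an amine at the same place would show whether other groups can match it.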